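Swapping Methoxy for Isopropyl in Compound 1

The source may report more compounds than this note shows. Statements on the series, on what has been measured and on what is new or still open speak of the compounds shown alone.

Within the data shown here, compound 1 `COc1ccccc1N1CCN(CCCNc2ncccc2C(=O)N(C)C)CC1` was tested in a functional assay for antagonist activity at Alpha-1A adrenergic receptor (Oryctolagus cuniculus) (a higher number here means weaker binding, a lower number tighter binding), and gives 1.59 nM, the lowest of the three numbers measured so far. Compound 2 `COc1ccccc1N1CCN(CCCSc2ccccc2C(=O)N(C)C)CC1` gives 2 nM, which lies within the usual scatter of the value for compound 1, so the two cannot be told apart. Compound 3 `COc1ccccc1N1CCN(CCCNc2ccccc2C(=O)c2ccccc2)CC1` gives 31.6 nM, a gap beyond the scatter. Compound 4 `CC(C)c1ccccc1N1CCN(CCCNc2ncccc2C(=O)N(C)C)CC1` has not yet been measured; it differs from compound 1 by isopropyl in place of methoxy on an aromatic carbon. Among the measured compounds shown here, no measured pair shows this exchange, so its effect is uncertain. Compound 4 is expected to show a somewhat higher number, an estimated step of a 3.1-fold higher number from compound 1 to compound 4 (0.50 log units; beyond the scatter). Compound 4 is therefore estimated at 5 nM, with a likely range from 1.5 nM to 16 nM.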

Compound 4, dissociation constant: 0.398 nM
Beside the measured number, compound 4's estimate is 13-fold (1.10 log units) above it, and the stated range ends above it.
By their numbers in this assay, from the lowest: compound 4; then compounds 1 and 2 (each within the scatter of the next); then compound 3.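

Isopropyl in place of methoxy on this aromatic carbon gives a 4.0-fold lower number from compound 1 to compound 4 (0.60 log units; beyond the scatter) in this assay. Compounds 1, 2 and 3 all carry methoxy here, so only this result shows that the place tolerates a change, and that tight binding survives the loss of the methoxy oxygen. No available data explain why the number falls. As far as these compounds go, whether ethyl, tert-butyl or a chlorine atom in this place would do as well remains open. So does whether the same exchange would lower the number for compound 2 or compound 3.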